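Ortho ethyl replacing dimethylamino on a pyridazine sulfonamide series

The compounds below may be only part of what the source reports. "The series", "measured", "known", "first", "only" and "open" are said of these compounds alone.

Of the compounds shown here, three have been measured in an assay on mitochondria from liver for inhibition of kynurenine 3-monooxygenase (Mus musculus), read by LC-MS, with stated times of 5 min and 30 min; on this read-out lower numbers stand for stronger inhibition and higher numbers for weaker inhibition. Compound 1 `Cc1cccc(S(=O)(=O)Nc2ccc(-c3cccc(Cl)c3)nn2)c1` gives 101 nM, compound 2 `Cc1ccc(S(=O)(=O)Nc2ccc(-c3ccccc3N(C)C)nn2)cc1` gives 4.5 nM, and compound 3 `Cc1ccc(S(=O)(=O)Nc2ccc(-c3cccc4cccnc34)nn2)cc1` gives 8.7 nM. Compound 2 carries the lowest number of the three; compound 3 lies within the usual scatter of it, while compound 1 stands beyond that scatter. Compound 4 `CCc1ccccc1-c1ccc(NS(=O)(=O)c2ccc(C)cc2)nn1` has not been measured in this assay. It differs from compound 2 by ethyl in place of dimethylamino on an aromatic carbon. Among the compounds with values here, no step between measured compounds covers this exchange, so the direction rests on expectation alone. A modest shift toward a higher number is expected from compound 2, a 2.2-fold higher number from compound 2 to compound 4 (0.35 log units; beyond the scatter). Compound 4 is therefore estimated at 10 nM, within a range of 3 nM to 35 nM.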

Compound 4, half-maximal inhibitory concentration: 29.2 nM
Compound 4: middle estimate off by 2.9-fold (0.47 log units), on the low side; low and high end bracket the measured number.
By their numbers in this assay, from the lowest: compounds 2 and 3 (each within the scatter of the next); then compound 4; then compound 1.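

Within the data shown here, the step of a 6.5-fold higher number from compound 2 to compound 4 (0.81 log units; beyond the scatter) is the first reading at this position, and it shows that the number here responds to exchanging dimethylamino for ethyl on an aromatic carbon ortho to a large group. The exchange takes away the one hydrogen-bond acceptor and one heavy atom, and these compounds cannot separate the two changes. Nothing available accounts for the shift. From the compounds shown here alone, whether a methoxy group, a methylamino group or a longer chain in this place would give a number like that of compound 2 remains open. So does whether the step holds when the shared core is changed elsewhere.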